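This account rests on a few compounds, and the source may have more. Where it says the series, first, only, none or still open, it means among the compounds named here.

Two compounds have numbers in an assay on membranes from brain for displacement of a labelled ligand from Sigma non-opioid intracellular receptor 1 (Cavia porcellus); on this read-out lower numbers stand for stronger inhibition and higher numbers for weaker inhibition. Compound 1 `CCCN(C)CCCCCc1ccccc1` gives 0.29 nM in this assay. Compound 2 `c1ccc(CCCCCN2CCCC(c3ccccc3)C2)cc1` gives 0.14 nM in this assay, the lower of the two numbers; the gap to compound 1 lies beyond the usual scatter, so compound 2 stands as the stronger of the pair. Compound 3 `c1ccc(CCCCCN2CCCCC2)cc1` has not been measured in this assay. It differs from compound 2 by hydrogen in place of phenyl on a saturated ring carbon. Among the measured compounds shown here, no measured pair shows this change on its own. Compound 1 shows that an open-chain amine carrying no phenyl on a ring already reaches 0.29 nM, so any loss from removing the phenyl is expected to be modest. The expected step is a 3.6-fold higher number from compound 2 to compound 3 (0.55 log units; beyond the scatter), toward weaker inhibition, at or just beyond the scatter. For compound 3 the estimate in this assay is 0.5 nM, within a range from 0.15 nM to 2 nM.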

Compound 3, inhibition constant: 0.38 nM
The estimate for compound 3 lay 1.3-fold (0.12 log units) above the measured number; measured number inside the range.
By their numbers in this assay, from the lowest: compound 2; then compounds 1 and 3 (each within the scatter of the next).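

In this assay, among the compounds shown here, hydrogen in place of phenyl on a saturated ring carbon, two ring bonds from the ring nitrogen, gives a 2.7-fold higher number from compound 2 to compound 3 (0.43 log units; beyond the scatter), the first direct reading of this change at this position. The step is modest but runs toward weaker inhibition, and compound 3 still gives 0.38 nM, so the phenyl at this position is not needed for strong inhibition in this series. The data offer no measured basis for explaining this step.

The compounds shown leave open how a methyl, a hydroxyl or a benzyl group on the same ring carbon would compare with hydrogen and phenyl. They also leave open whether the same change would give a step of similar size with a longer chain on the ring nitrogen.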